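The compounds below may be only part of what the source reports. "The series", "measured", "known", "first", "only" and "open" are said of these compounds alone.

Of the compounds shown here, three have been read so far in a physicochemical assay for solubility, read by nephelometry, in phosphate buffer, measured as kinetic solubility, at pH 6.5 (on this read-out higher numbers stand for higher solubility and lower numbers for lower solubility), and they sit close together. Compound 3 (`O=C(Nc1ccc(F)c(C(F)(F)F)c1)Nc1ccccn1`) gives < 1.6 ug/mL in this assay and that figure is a limit and not a number. Compound 1 (`CC(=O)c1ccc(NC(=O)Nc2ccc(F)c(C(F)(F)F)c2)cc1`) gives < 1.6 ug/mL in the same test, which is again a limit. Only compound 2 (`N#Cc1ccc(NC(=O)Nc2ccnc(C(F)(F)F)c2)cc1`) returns an actual number, 1.6 ug/mL in this case. On these data alone, the set is therefore marked by the limit of < 1.6 ug/mL in this assay, at which 2 of the 3 values shown sit, and the true position of compound 3 remains unknown.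

Compound 4 (`O=C(Nc1cccnc1)Nc1ccc(F)c(C(F)(F)F)c1`) has pyridin-3-yl in place of pyridin-2-yl on an amide-type nitrogen, a change that keeps the same atoms but joins them differently (pyridin-3-yl in place of pyridin-2-yl on an amide-type nitrogen). Within the data shown here, no measured pair in the set differs in one place only, so the data do not show directly what a swap of this kind does. Among the measured compounds shown here, the one number available, compound 2 at 1.6 ug/mL in this assay, gives no sign of a compound standing far from the others. What is expected is an at least 1.5-fold higher number from compound 3 to compound 4 (0.19 log units; that floor lies within the scatter) as a small rise that may well stay within the scatter. The estimated solubility of compound 4 is 2.5 ug/mL (expected range 1 ug/mL to 8 ug/mL) and a reading reported only as a limit would be no surprise.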

Compound 4, solubility: 12.5 ug/mL
Compound 4: middle estimate off by 5.0-fold (0.70 log units), on the low side, outside the stated range (above it).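

Among these compounds, compound 3 and compound 4 form the first pair in the set that differs in one place only, and in this assay this pair gives an at least 7.8-fold higher number from compound 3 to compound 4 (0.89 log units; beyond the scatter), a step that lies beyond the scatter. The two compounds hold the same atoms, so this step goes with nothing more than how the ring is joined on the amide-type nitrogen, with pyridin-3-yl in place of pyridin-2-yl, and it shows that this position does not read the same for these two attachments even though the counts of atoms, donors and acceptors stay the same. The step is only a floor and its true size cannot be given, because the reading for compound 3 is a limit and not a number: the limit of < 1.6 ug/mL in this assay, at which 2 of the 4 values shown sit.

What the compounds shown leave open is how large the step really is and whether the same swap would give a step of similar size on a different core, such as that of compound 2. They also leave open how this position would read with a different group on the amide-type nitrogen, such as a piperidine or a ring carrying a carboxylic acid.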